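Working notes: the step from compound 2 to compound 3

The source may hold more compounds than are shown below. What is called first, only, known or untested is meant among the compounds shown, and "the series" means these compounds.

Measured in an ADME assay on BJ cells (Homo sapiens) for cytotoxicity, with a stated time of 72 h; a higher number here means that more compound is needed for the effect, a lower number that less compound is needed
- compound 1 `COc1cc2ncnc(-n3nc(-c4ccc(Cl)cc4)nc3N)c2cc1OC` gives > 50000 nM
- compound 2 `COc1cc2ncnc(Nc3ccccn3)c2cc1OC` gives > 27000 nM

Compound 2 stands at a limit (> 27000 nM), not at a number. Compound 1 also stands at a limit (> 50000 nM). Compound 3 `COc1cc2ncnc(-n3nc(N)nc3N)c2cc1OC` carries 3,5-diamino-1H-1,2,4-triazol-1-yl in place of the (pyridin-2-yl)amino of compound 2, on an aromatic carbon of the shared core (3,5-diamino-1H-1,2,4-triazol-1-yl in place of (pyridin-2-yl)amino on an aromatic carbon). In this assay a small upward step, not beyond the scatter, is expected (a step that the limit leaves unreadable from compound 2 to compound 3). Compound 3 is estimated at 40000 nM (range 15000 nM to 100000 nM).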

Compound 3, half-maximal effective concentration: > 33000 nM
Compound 3: a limit, no number; the forecaster's own chance of this, stated with the estimate: 70%; the middle value does not contradict the limit.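

Compound 3, like compound 1 and compound 2, gives only a limit in this assay, so neither the step from compound 2 to compound 3 nor that from compound 1 to compound 3 can be read. The compounds shown leave open whether either replacement changes cytotoxicity at all.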